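The source may report more compounds than this note shows. Statements on the series, on what has been measured and on what is new or still open speak of the compounds shown alone.

Measured so far in a physicochemical assay for solubility, read by mass spectrometry, in phosphate buffer, with a stated time of 24 h, at pH 7.4; on this read-out lower numbers stand for lower solubility and higher numbers for higher solubility:

- compound 1, `O=C(Nc1ccc(OC(F)(F)F)cc1)NC1CCN(C(=O)C2CCCOC2)CC1`: 94 ug/mL
- compound 2, `O=C(Nc1ccc(C(F)(F)F)cc1)NC1CCN(C(=O)c2ccoc2)CC1`: 2.2 ug/mL
- compound 3, `O=C(Nc1ccc(C(F)(F)F)cc1)NC1CCN(C(=O)C2CCOC2)CC1`: 9.6 ug/mL

Compound 3 stands second highest of the three numbers in this assay; its nearest neighbour is compound 2, lower by the step of a 4.4-fold higher number from compound 2 to compound 3 (0.64 log units; beyond the scatter), and the furthest is compound 1, whose number is markedly higher. No single-change step is shown between compound 1 and compound 3, as they differ both in the ring on the carbonyl and in the substituent on the aryl ring; only their two values are known.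

The next compound is compound 4, `O=C(Nc1ccc(C(F)(F)F)cc1)NC1CCN(C(=O)C2CCCOC2)CC1`. It differs from compound 3 as follows: oxan-3-yl in place of oxolan-3-yl on a carbonyl carbon. Going by the values given here, only one measured step bears on this position, the step of a 4.4-fold higher number from compound 2 to compound 3 (0.64 log units; beyond the scatter), and it concerns a different exchange on the same carbonyl carbon, so it gives direction for the site but not for this change. Compound 1 carries the entering oxan-3-yl group yet sits on another aryl substituent, so its value 94 ug/mL is only indirect support. A small step is therefore expected in this assay, most likely upward, a 1.4-fold higher number from compound 3 to compound 4 (0.13 log units; within the scatter), with a wide range, and the value of compound 4 is estimated at 13 ug/mL, between 4 ug/mL and 40 ug/mL.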

Compound 4, solubility: 1.1 ug/mL
Estimate against measurement, compound 4: 12-fold (1.07 log units) above; the measured number lies below the stated range.
By their numbers in this assay, from the lowest: compounds 4 and 2 (each within the scatter of the next); then compound 3; then compound 1.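

In this assay, going by these compounds alone, the exchange on the carbonyl carbon is not the small step the earlier compounds left room for: going from the five-membered oxolan-3-yl to the six-membered oxan-3-yl gives an 8.7-fold lower number from compound 3 to compound 4 (0.94 log units; beyond the scatter), so ring size alone matters at this position, and oxolan-3-yl stands clear of the other two rings with a trifluoromethyl aryl group. Within the data shown here, the oxan-3-yl ring and the aromatic furan-3-yl ring are not separated in this assay, with a 2.0-fold lower number from compound 2 to compound 4 (0.30 log units; within the scatter), while the first single-change step at the aryl substituent is the largest, an 85-fold lower number from compound 1 to compound 4 (1.93 log units; beyond the scatter), which shows that the number of compound 1 does not carry over to the trifluoromethyl compound with the same oxan-3-yl ring. No evidence at hand accounts for the size or direction of these steps.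

Still open is whether the oxolan-3-yl to oxan-3-yl step keeps its direction and size with trifluoromethoxy on the aryl ring, as the compounds shown offer that substituent only with oxan-3-yl. Also open, going by these compounds, is how a carbonyl substituent carrying an amine or a carboxylic acid would read in this assay.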